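The compounds below may be only part of what the source reports. "The series", "measured", "known", "first", "only" and "open" are said of these compounds alone.

Measured in a functional assay on DU-145 cells (Homo sapiens) for cytotoxicity, read by MTT assay; a lower number here means a stronger inhibitor, a higher number a weaker inhibitor:

- compound 1 `CC(C)=CC[C@@H](OC[C@@H](C)O)C1=CC(=O)c2c(O)ccc(O)c2C1=O`: 14300 nM
- compound 2 `CCCCC(O)CC(=O)O[C@H](CC=C(C)C)C1=CC(=O)c2c(O)ccc(O)c2C1=O`: 45300 nM
- compound 3 `CCCCCCC(C)(O)CC(=O)O[C@H](CC=C(C)C)C1=CC(=O)c2c(O)ccc(O)c2C1=O`: only a limit, > 100000 nM

Among the compounds with values here, compound 3 therefore stands at the weak end of what was measured: in this assay its result is a limit of the assay and not a number, the one value among the three that sits at the limit of > 100000 nM in this assay, at which 1 of the 3 values shown sits. Compound 4 `CC(C)=CC[C@@H](OC(=O)C1CCCCO1)C1=CC(=O)c2c(O)ccc(O)c2C1=O` differs from it in one place: oxan-2-yl in place of 2-hydroxy-2-methyloctyl on a carbonyl carbon. Both steps measured so far bear on this position. Going from the ether to an ester carrying a hydroxylated chain gave a 3.2-fold higher number from compound 1 to compound 2 (0.50 log units; beyond the scatter), and lengthening and branching that chain gave an at least 2.2-fold higher number from compound 2 to compound 3 (0.34 log units; beyond the scatter). Compound 4 keeps the ester but carries a smaller ring in place of the long chain, so it lies structurally between compound 2 and compound 3. Compound 4 is therefore expected to give a modest step down, an at least 1.6-fold lower number from compound 3 to compound 4 (0.22 log units; that floor lies within the scatter), towards the value of compound 2. The estimate for compound 4 in this assay is 60000 nM, expected to fall between 20000 nM and 200000 nM, with a real chance that only a limit is reported.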

Compound 4, half-maximal inhibitory concentration: 24700 nM
Compound 4: middle estimate off by 2.4-fold (0.39 log units), on the high side, within the range that was stated.
By their numbers in this assay, from the lowest: compounds 1, 4 and 2 (each within the scatter of the next, the first and the last beyond it). At a limit, above all of these: compound 3.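

In this assay, the ester link does not by itself set the result; the group on the carbonyl carbon matters, and oxan-2-yl in place of 2-hydroxy-2-methyloctyl gives an at least 4.0-fold lower number from compound 3 to compound 4 (0.60 log units; beyond the scatter). From the compounds shown here alone, the result for compound 3 is only a limit of the assay, so the true size of this step stays unknown: the limit of > 100000 nM in this assay, at which 1 of the 4 values shown sits. Compound 4 goes against the earlier impression that moving from the ether to an ester raises the number, since the differences are within the scatter both for the other ester, with a 1.8-fold lower number from compound 2 to compound 4 (0.26 log units; within the scatter), and for the ether, with a 1.7-fold higher number from compound 1 to compound 4 (0.24 log units; within the scatter).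

The compounds shown cannot separate the effect of having a ring from that of having a smaller group, and they do not show whether the ring oxygen of oxan-2-yl counts for anything. A cyclohexyl group on the same carbonyl carbon would test the oxygen, and a plain hexyl chain without a hydroxyl would test whether the hydroxyl on the open chains matters.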